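Methyl on the Amide Nitrogen: Expected Lipophilicity Shift

A few compounds are considered here, and "the series" means these few. Any claim that something is new, unique, unknown or untested is made for them only; others in the source may bear on it.

Compound 2 `NC(=O)[C@H]1CN(c2ccc(-n3cc(-c4ccccn4)cn3)c(F)c2)C(=O)O1` gives 1.59 in a physicochemical assay for lipophilicity, read by HPLC, measured as octanol-water partition; a higher number here means a more lipophilic compound, a lower number a more polar compound. Compound 1 `CN(C)S(=O)(=O)NC[C@H]1CN(c2ccc(-n3cc(-c4ccccn4)cn3)c(F)c2)C(=O)O1` gives 1.38 in this assay, and the step of a number 0.21 log units higher from compound 1 to compound 2 (within the scatter) lies within the scatter, so the two numbers cannot be ordered. Compound 3 `CNC(=O)[C@H]1CN(c2ccc(-n3cc(-c4ccccn4)cn3)c(F)c2)C(=O)O1` differs from compound 2 by methyl in place of hydrogen on an amide-type nitrogen. Among the compounds with values here, the one measured step exchanges a whole side chain and does not touch this amide nitrogen, so it gives no direct guide. Compound 3 is estimated at 1.95, between 1.6 and 2.3. The expected step is a number 0.36 log units higher from compound 2 to compound 3 (beyond the scatter), small and near the edge of the scatter.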

Compound 3, partition coefficient: 1.39
Compound 3: the middle estimate sits 0.56 log units above what was measured; the whole stated range lies above it.
By their numbers in this assay, from the lowest: compounds 1, 3 and 2 (each within the scatter of the next).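

In this assay, methyl in place of hydrogen on the amide-type nitrogen gives a number 0.20 log units lower from compound 2 to compound 3 (within the scatter), so compound 2 and compound 3 cannot be ordered, and this single added carbon has no effect that can be told from the scatter. Methylcarbamoyl in place of ((dimethylsulfamoyl)amino)methyl gives a number 0.01 log units higher from compound 1 to compound 3 (within the scatter), so compound 1 and compound 3 cannot be ordered either. Nothing available explains these results.

Open, on these data alone, is whether a longer chain such as ethyl on this nitrogen would give a step beyond the scatter. As far as these compounds go, a carboxylic acid in place of carbamoyl is equally open.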